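A few compounds are considered here, and "the series" means these few. Any claim that something is new, unique, unknown or untested is made for them only; others in the source may bear on it.

Measured in an ADME assay on microsomes from liver (Homo sapiens) for metabolic stability, read by LC-MS, using NADPH, with stated times of 5 min and 30 min, tested at 1 uM; on this read-out higher numbers stand for fast clearance and lower numbers for slow clearance:

compound 1 `Cn1cc(-c2cnc(NCc3c(F)ccc4c3CCO4)c3cn[nH]c(=O)c23)cn1`: 21 mL.min-1.g-1
compound 2 `CN(C)Cc1ccc2c(c1)CN(c1cnc(NCc3c(F)ccc4c3CCO4)n3cnnc13)C2=O`: 19 mL.min-1.g-1
compound 3 `C[C@H]1CC(=O)N(c2cnc(NCc3c(F)ccc4c3CCO4)n3cnnc23)C1`: a limit of the assay, < 3 mL.min-1.g-1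

Of the two numbers, compound 1 gives the higher one, and compound 2 sits within the scatter of it, so the two are not distinguished. Compound 3 gives only a limit, (the limit of < 3 mL.min-1.g-1 in this assay, at which 1 of the 3 values shown sits), and no number.

Compound 4 `CNC(=O)c1cc(-c2cnc(NCc3c(F)ccc4c3CCO4)c3cn[nH]c(=O)c23)n(C)n1` differs from compound 1 in one place: 1-methyl-3-(methylcarbamoyl)-1H-pyrazol-5-yl in place of 1-methyl-1H-pyrazol-4-yl on an aromatic carbon. Among the compounds with values here, no measured pair carries a change of this kind, so there is no step to rest a direction on. The expectation for this assay is a decrease from compound 1 to compound 4 that is small, at the edge of the scatter, and a number rather than a limit is expected, since the change keeps the shared core of compound 1 and alters only the five-membered ring attached to it. On that basis compound 4 is estimated at 12 mL.min-1.g-1, within the range 5 mL.min-1.g-1 to 30 mL.min-1.g-1, which corresponds to the step of a 1.8-fold lower number from compound 1 to compound 4 (0.24 log units; within the scatter).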

Compound 4, intrinsic clearance in microsomes: < 3 mL.min-1.g-1
Compound 4: no number, only a limit (the forecaster's own chance of this, stated with the estimate: 12%); middle value at least 4.0-fold (0.60 log units) from the limit.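

In this assay, replacing 1-methyl-1H-pyrazol-4-yl with 1-methyl-3-(methylcarbamoyl)-1H-pyrazol-5-yl gives an at least 7.0-fold lower number from compound 1 to compound 4 (0.84 log units; beyond the scatter), the only single-place step readable in the compounds shown. It shows that, on this aromatic carbon of the shared core, a change confined to the five-membered ring can move the read-out beyond the scatter. Compound 4 gives only a limit, so this step has a bound and no measured size: the limit of < 3 mL.min-1.g-1 in this assay, at which 2 of the 4 values shown sit.

The methylcarbamoyl group and the changed attachment of the pyrazole enter together in compound 4, so the compounds shown do not separate their contributions. Also open, from the compounds shown here alone, is how the read-out would respond if a carboxylic acid or a nitrile stood in place of the methylcarbamoyl group on the same pyrazole.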